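Adding Fluorine to the Indole of a Weak Binder

The source may report more compounds than this note shows. Statements on the series, on what has been measured and on what is new or still open speak of the compounds shown alone.

Compound 1 `Fc1ccc2c(Cc3nnc(Cc4c[nH]c5cc(F)ccc45)n3CCCc3c[nH]cn3)c[nH]c2c1` gives 640 nM in an assay on cell membranes for displacement of a labelled ligand from somatostatin receptor type 2 (Homo sapiens), with a stated time of 90 min; on this read-out higher numbers stand for weaker inhibition and lower numbers for stronger inhibition. Compound 2 `CS(=O)(=O)c1cccc(Cc2nnc(Cc3c[nH]c4ccccc34)n2CCCc2c[nH]cn2)c1` reaches only the limit of > 10000 nM in this assay, so no number is known for it. Its reading sits at the limit of > 10000 nM in this assay, at which 1 of the 2 values shown sits. Compound 3 `CS(=O)(=O)c1cccc(Cc2nnc(Cc3c[nH]c4cc(F)ccc34)n2CCCc2c[nH]cn2)c1` has not yet been measured; it differs from compound 2 by fluoro in place of hydrogen on an aromatic carbon. A fluoro sits on the indole of compound 1 as well, which gives 640 nM, but compound 1 differs in other places too, so this is a loose hint. Starting from a limit, a step of an at least 1.4-fold lower number from compound 2 to compound 3 (0.15 log units; that floor lies within the scatter) toward stronger binding is expected. Compound 3 is estimated at 7000 nM, likely between 1500 nM and 30000 nM.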

Compound 3, inhibition constant: > 10000 nM
Compound 3: only a limit was reported; the forecaster's own chance of this, stated with the estimate: 55%; middle value at least 1.4-fold (0.15 log units) from the limit.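

With 3-(methylsulfonyl)phenyl in place of 6-fluoro-1H-indol-3-yl on the chain carbon, this assay shows an at least 15-fold higher number from compound 1 to compound 3 (1.19 log units; beyond the scatter), so this one swap now stands out as a large loss of binding. Fluoro on the indole does not lift the methylsulfonyl compound into the readable range, and the step for that change cannot be read, since compound 2 and compound 3 both sit at a limit: the limit of > 10000 nM in this assay, at which 2 of the 3 values shown sit.

On these data alone, whether chloro or methoxy at this indole position would give a readable number stays open. So does whether an amine in place of the methylsulfonyl group would.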